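The source may report more compounds than this note shows. Statements on the series, on what has been measured and on what is new or still open speak of the compounds shown alone.

Three analogues of a shared core were tested in a functional assay on MKN-45 cells (Homo sapiens) for inhibition, read by MTT assay, with a stated time of 72 h; a higher number here means a weaker inhibitor, a lower number a stronger inhibitor. Compound 1 `COc1cc2c(Oc3ccc(NC(=O)c4nn(-c5ccccc5C(F)(F)F)c(=O)cc4C)cc3F)ccnc2cc1OCCCN1CCN(C)CC1` gives 40 nM; compound 2 `COc1cc2c(Oc3ccc(NC(=O)c4nn(-c5cccc(F)c5)c(=O)cc4C)cc3F)ccnc2cc1OCCCN1CCN(C)CC1` gives 120 nM; compound 3 `COc1ccc(-n2nc(C(=O)Nc3ccc(Oc4ccnc5cc(OCCCN6CCN(C)CC6)c(OC)cc45)c(F)c3)c(C)cc2=O)cc1` gives 1230 nM, the highest number of the three. The steps of a 31-fold higher number from compound 1 to compound 3 (1.49 log units; beyond the scatter) and a 10-fold higher number from compound 2 to compound 3 (1.01 log units; beyond the scatter) were large, and a 3.0-fold higher number from compound 1 to compound 2 (0.48 log units; beyond the scatter) modest. Compound 4 `COc1cc2c(Oc3ccc(NC(=O)c4nn(-c5ccc(Cl)cc5)c(=O)cc4C)cc3F)ccnc2cc1OCCCN1CCN(C)CC1` differs from compound 3 by chloro in place of methoxy on an aromatic carbon. Among the measured compounds shown here, no measured pair shows this exchange; the steps into compound 3 only show that its 4-methoxyphenyl sits furthest from the others. For compound 4 a modest step downward, a 3.1-fold lower number from compound 3 to compound 4 (0.49 log units; beyond the scatter), is therefore expected, with wide uncertainty. Compound 4 is estimated at 400 nM, between 100 nM and 1500 nM.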

Compound 4, half-maximal inhibitory concentration: 40 nM
Beside the measured number, compound 4's estimate is 10-fold (1.00 log units) above it, and the stated range ends above it.
By their numbers in this assay, from the lowest: compounds 1 and 4 (each within the scatter of the next); then compound 2; then compound 3.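

In this assay, chloro in place of methoxy on the same aromatic carbon gives a 31-fold lower number from compound 3 to compound 4 (1.49 log units; beyond the scatter) and so ties the weak result of compound 3 to the methoxy, not to having a group at this place as such. The 4-chlorophenyl also gives a 3.0-fold lower number from compound 2 to compound 4 (0.48 log units; beyond the scatter) against the 3-fluorophenyl, and against the 2-(trifluoromethyl)phenyl it shows no change at the digits printed from compound 1 to compound 4 (within the scatter) at this stage of the series. On these data alone, whether a methyl or an amine at this place would follow chloro or methoxy stays open. Nothing given here accounts for the gap between chloro and methoxy.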